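Swapping the phenyl of compound 1 for a thiophene

This account rests on a few compounds, and the source may have more. Where it says the series, first, only, none or still open, it means among the compounds named here.

The study concerns a set of compounds sharing one core, tested in a functional assay on the whole organism (strain Wistar) for inhibition, with Rattus norvegicus as the target, read by paw edema, with stated times of 30 min and 3 h, at a dose of 200 mg/kg by the oral route; on this read-out lower numbers stand for less inhibition and higher numbers for more inhibition at the one dose given (going by the name of the read-out). Compound 1, of structure `O=C(O)c1cc(-n2c(-c3ccccc3)cc3c2CCCC3)ccc1O`, is the starting point. In this assay compound 1 gives >= 60%, which is a limit of the assay and not a number, so only a lower bound is known for it (the limit of >= 60% in this assay, at which 1 of the 3 values shown sits). Compound 2, of structure `O=C(O)c1cc(-n2c(-c3ccccc3)cc3c2CCCC3)ccc1Cl`, gives 40% in this assay. Compound 3, of structure `O=C(O)c1cc(-n2c(-c3ccccc3)cc3c2CCCC3)cc(Br)c1O`, gives 0% in this assay. The two measured steps both run downward: a number at least 20 percentage points lower from compound 1 to compound 2 (beyond the scatter), and a number at least 60 percentage points lower from compound 1 to compound 3 (beyond the scatter).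

The compound still to be measured is compound 4, of structure `O=C(O)c1cc(-n2c(-c3cccs3)cc3c2CCCC3)ccc1O`. It differs from compound 1 by thiophen-2-yl in place of phenyl on an aromatic carbon. Neither measured step bears directly on this change: both concern chloro in place of hydroxy or bromo in place of hydrogen elsewhere in the molecule, while the aryl group on the five-membered ring is kept unchanged in compounds 2 and 3. Within the data shown here, the data thus give no measured step for an aryl exchange at this place. In the absence of such a step, compound 4 is expected to stay near compound 1, with a step of a number at least 5 percentage points lower from compound 1 to compound 4 (that floor lies within the scatter) that is not expected to exceed the scatter. Compound 4 is therefore estimated at 55% in this assay, within a range from 35% to 75%.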

Compound 4, a percentage reported as inhibition, in the whole organism at one dose (the size of the read-out at that dose, not a potency): 30%
Compound 4: the middle estimate sits 25 percentage points above what was measured; measured number outside the range, below it.
By their numbers in this assay, from the lowest: compound 3; then compounds 4 and 2 (each within the scatter of the next). At a limit, above all of these: compound 1.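

In this assay, the group on this aromatic carbon of the five-membered aromatic ring, next to the ring nitrogen, proves sensitive to exchange: thiophen-2-yl in place of phenyl gives a number at least 30 percentage points lower from compound 1 to compound 4 (beyond the scatter). Among these compounds, the earlier steps kept phenyl unchanged and showed a response only to changes elsewhere in the molecule, so this is the first sign that the read-out also depends on the aryl group at this place, and that a six-membered aromatic ring of carbon cannot be replaced here by a five-membered aromatic ring with one hetero atom without a loss beyond the scatter. The value of compound 1 is a limit of the assay and not a number, so this step is known only as a floor and its full size stays unknown: the limit of >= 60% in this assay, at which 1 of the 4 values shown sits.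

With a single exchange at this place, the compounds shown do not tell whether the step follows from the smaller ring or from the sulfur atom. Also open, going by these compounds, is how thiophen-3-yl, furan-2-yl, a pyridine ring or a phenyl carrying a methoxy group would read at this place.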